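This account rests on a few compounds, and the source may have more. Where it says the series, first, only, none or still open, it means among the compounds named here.

Measured compounds and their values in an assay on isolated protein for inhibition of Amine oxidase [flavin-containing] B (Homo sapiens), read by Amplex Red, with a stated time of 15 min; a lower number here means a stronger inhibitor, a higher number a weaker inhibitor:
- compound 1 `CC(=O)c1ccc(OCc2cccc(C)c2)cc1`: 86.3 nM
- compound 2 `CC(=O)c1ccc(OCc2ccc(C)cc2)cc1`: 102 nM
- compound 3 `CC(=O)c1ccc(OCc2cccc([N+](=O)[O-])c2)cc1`: 104 nM

Compound 2 gives 102 nM in this assay, the second highest of these three numbers, and both compound 1 and compound 3 lie within the scatter of it, so the three are not told apart here.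

Compound 4 `CC(=O)c1ccc(OCc2ccc([N+](=O)[O-])cc2)cc1` differs from compound 2 in one place: nitro in place of methyl on an aromatic carbon. One measured step is of the same kind, a 1.2-fold higher number from compound 1 to compound 3 (0.08 log units; within the scatter), and it stayed within the scatter. On that basis no step beyond the scatter is expected in this assay for compound 4 either.

Compound 4 is therefore estimated at 120 nM, with a range from 60 nM to 250 nM, meaning an expected step of a 1.2-fold higher number from compound 2 to compound 4 (0.07 log units; within the scatter).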

Compound 4, half-maximal inhibitory concentration: 96.5 nM
Compound 4: the middle estimate sits 1.2-fold (0.09 log units) above what was measured, and the stated range covers the measured number.
By their numbers in this assay, from the lowest: compounds 1, 4, 2 and 3 (each within the scatter of the next).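

In this assay, nitro in place of methyl on the aromatic carbon para to a large group gives a 1.1-fold lower number from compound 2 to compound 4 (0.02 log units; within the scatter), so three heavy atoms in place of one make no step beyond the scatter at this position either. The change now reads the same in two places: the same change on two cores in this assay, a 1.2-fold higher number (0.08 log units; within the scatter) from compound 1 to compound 3 and a 1.1-fold lower number (0.02 log units; within the scatter) from compound 2 to compound 4, 1.3-fold (0.11 log units) apart, within the scatter of two such steps.

On these data alone, with only methyl and nitro on this ring, it stays open whether an amine, a carboxylic acid or a longer chain here would shift the number beyond the scatter. Why methyl and nitro read alike also stays open.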